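Extending an azido chain by one ethoxy unit

This account rests on a few compounds, and the source may have more. Where it says the series, first, only, none or still open, it means among the compounds named here.

Compound 1 `CCOC(=O)c1cn(Cc2c(F)cccc2F)c2nc(-c3ccc(NC(=O)NCc4cn(CCN=[N+]=[N-])nn4)cc3)c(CN(C)Cc3ccccc3)n2c1=O`: 2570 nM
Compound 2 `CCNC(=O)Nc1ccc(-c2nc3n(Cc4c(F)cccc4F)cc(C(=O)NCc4cn(CCOCCN=[N+]=[N-])nn4)c(=O)n3c2CN(C)Cc2ccccc2)cc1`: < 10000 nM

Both compounds were tested in a functional assay on CHO cells for antagonist activity at Gonadotropin-releasing hormone receptor (Homo sapiens), read by a luciferase reporter, with a stated time of 30 min; a lower number here means a stronger inhibitor, a higher number a weaker inhibitor. Compound 1 gives 2570 nM in this assay. For compound 2 the result is only a limit, < 10000 nM, so no number is known for it, only that it sits within that limit (the limit of < 10000 nM in this assay, at which 1 of the 2 values shown sits). For the measured compounds named here, no step between these two compounds is given, and their values show no more than that.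

Compound 3 `CCNC(=O)Nc1ccc(-c2nc3n(Cc4c(F)cccc4F)cc(C(=O)NCc4cn(CCOCCOCCN=[N+]=[N-])nn4)c(=O)n3c2CN(C)Cc2ccccc2)cc1` has not been measured. It differs from compound 2 by 2-azidoethoxy in place of azido on a saturated chain carbon, two bonds along the chain from an oxygen on a saturated carbon: the chain that already carries an oxygen on a saturated carbon is lengthened by one more ethoxy unit before the terminal azide, while the rest of the molecule is unchanged. Going by the values given here, there is no measured pair of this kind to lean on. The expected step in this assay is a step that the limit leaves unreadable from compound 2 to compound 3, nothing beyond the usual scatter in either direction. Compound 3 is therefore estimated at 4000 nM, with a range from 1000 nM to 12000 nM, and with a real chance that this assay again reports only a limit.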

Compound 3, half-maximal inhibitory concentration: < 10000 nM
Compound 3 gave a limit, no number; the forecaster's own chance of this, stated with the estimate: 35%; the middle value lies beyond the limit too.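

Compound 2 and compound 3 each give only a limit in this assay, so no step can be read between them: the limit of < 10000 nM in this assay, at which 2 of the 3 values shown sit.

The compounds shown leave open whether 2-azidoethoxy in place of azido on this saturated chain carbon changes the strength of inhibition at all and, if it does, in which direction.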